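From Oxazole to Pyridinylamine: Expected Change in Solubility

The source may report more compounds than this note shows. Statements on the series, on what has been measured and on what is new or still open speak of the compounds shown alone.

Compound 1 `O=C(NCC1(c2nc(-c3ccccc3)cs2)CCOCC1)c1ccc(-c2cnco2)cc1` is the starting point. Going by the values given here, in a physicochemical assay for solubility, read by chemiluminescence, in phosphate buffer, measured as kinetic solubility, at pH 7.4 (a higher number here means a more soluble compound, a lower number a less soluble compound), compound 1 gives 71000 nM, the highest of the two numbers measured so far. Compound 2 `Cc1cc(C)n(-c2ccc(C(=O)NCC3(c4nc(-c5ccccc5)cs4)CCOCC3)cc2)n1` carries the same core but a different group on one aromatic carbon; in this assay compound 2 gives 33000 nM. Among the compounds with values here, the single measured step between them, a 2.2-fold lower number from compound 1 to compound 2 (0.33 log units; beyond the scatter), shows that swapping the ring at this position moves solubility by a modest amount, and in this case downward.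

Compound 3 `O=C(NCC1(c2nc(-c3ccccc3)cs2)CCOCC1)c1ccc(Nc2ccccn2)cc1` has not yet been measured. It differs from compound 1 by (pyridin-2-yl)amino in place of 1,3-oxazol-5-yl on an aromatic carbon. Within the data shown here, the only measured step that bears on this exchange is a 2.2-fold lower number from compound 1 to compound 2 (0.33 log units; beyond the scatter), since it also replaces the same group at the same position. That step was modest, and a change of similar size seems a reasonable expectation here, again downward, since the entering group is larger. Compound 3 is therefore expected to give 28000 nM in this assay, with a likely range from 9000 nM to 70000 nM. This estimate corresponds to an expected step of a 2.5-fold lower number from compound 1 to compound 3 (0.40 log units; beyond the scatter).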

Compound 3, solubility: 12000 nM
For compound 3 the middle estimate is 2.3-fold (0.37 log units) above the measured one, within the range that was stated.
By their numbers in this assay, from the lowest: compound 3; then compound 2; then compound 1.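

In this assay, placing (pyridin-2-yl)amino on this aromatic carbon, where compound 1 carries 1,3-oxazol-5-yl, gives a 5.9-fold lower number from compound 1 to compound 3 (0.77 log units; beyond the scatter) as the step, so a second replacement at this place also lowers the number, and further than the dimethylpyrazole of compound 2 did. The entering groups are not interchangeable either: a 2.8-fold lower number from compound 2 to compound 3 (0.44 log units; beyond the scatter) is the step between them, which shows that the number depends on which group stands here and not only on the loss of 1,3-oxazol-5-yl. No measurement is available that explains why the number fell.

The exchange from compound 1 to compound 3 alters several things at once, since the entering group has more heavy atoms, a six-membered rather than a five-membered aromatic ring, and a hydrogen-bond donor that the leaving group lacks, so the compounds shown cannot tell which of these goes with the lower number. A plain amino group or a carboxylic acid on the same aromatic carbon, with the shared core unchanged, would help to separate the contribution of the nitrogen link from that of the pyridine ring.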